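A few compounds are considered here, and "the series" means these few. Any claim that something is new, unique, unknown or untested is made for them only; others in the source may bear on it.

In a physicochemical assay for solubility, in phosphate buffer, at pH 7.4 (a higher number here means a more soluble compound, a lower number a less soluble compound), three compounds sharing one core have been measured. Compound 1 `CCOC(=O)c1c(-c2cccc([N+](=O)[O-])c2)[nH]c2cc(OC)ccc2c1=O`, which carries 3-nitrophenyl, gives 13000 nM. Compound 2 `CCOC(=O)c1c(-c2cccc(C(F)(F)F)c2)[nH]c2cc(OC)ccc2c1=O`, with trifluoromethyl in place of nitro, gives 19000 nM. That change amounts to a 1.5-fold higher number from compound 1 to compound 2 (0.16 log units; within the scatter). Compound 3 `CCOC(=O)c1c(-c2cccs2)[nH]c2cc(OC)ccc2c1=O`, which carries thiophen-2-yl, gives > 100000 nM. This value is a limit of the assay and not a number, so compound 3 stands at the limit of > 100000 nM in this assay, at which 1 of the 3 values shown sits.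

Compound 4 `CCOC(=O)c1c(-c2cccc(Cl)c2)[nH]c2cc(OC)ccc2c1=O` has not yet been measured. It has 3-chlorophenyl in place of the thiophen-2-yl of compound 3 (3-chlorophenyl in place of thiophen-2-yl on an aromatic carbon), on an aromatic carbon next to the ring nitrogen and ortho to an ethoxycarbonyl group.

Among the compounds with values here, two measured steps bear on this change. The closest is an at least 7.6-fold higher number from compound 1 to compound 3 (0.88 log units; beyond the scatter), which replaced 3-nitrophenyl with thiophen-2-yl, and the change to compound 4 runs the opposite way. The other, a 1.5-fold higher number from compound 1 to compound 2 (0.16 log units; within the scatter), suggests that compound 4 may sit close to compound 1 and compound 2, whose values lie within the scatter of each other. A fall of at least similar size is therefore expected in this assay. The expected step is an at least 6.2-fold lower number from compound 3 to compound 4 (0.79 log units; beyond the scatter). The estimate for compound 4 is 16000 nM, with an expected range of 6000 nM to 45000 nM.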

Compound 4, solubility: 58000 nM
The estimate for compound 4 lay 3.6-fold (0.56 log units) below the measured number; measured number outside the range, above it.
By their numbers in this assay, from the lowest: compounds 1 and 2 (each within the scatter of the next); then compound 4. At a limit, above all of these: compound 3.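

In this assay, the change at this position gives an at least 1.7-fold lower number from compound 3 to compound 4 (0.23 log units; that floor lies within the scatter), so the floor of this step does not by itself establish a real fall on leaving thiophen-2-yl. Compound 3 stands at a limit of the assay and not at a number: the limit of > 100000 nM in this assay, at which 1 of the 4 values shown sits.

The earlier pair, with nitro and trifluoromethyl on the same aromatic ring, had stayed within the scatter and gave no sign that the group on that ring matters, but chloro now separates from both, with a 3.1-fold higher number from compound 2 to compound 4 (0.48 log units; beyond the scatter) and a 4.5-fold higher number from compound 1 to compound 4 (0.65 log units; beyond the scatter), so the three compounds carrying a substituted phenyl ring no longer read as one level. The pattern holds only for these three, and compound 3, with its different ring, stands outside it.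

Going by these compounds, how far compound 4 truly lies from compound 3 stays open as long as thiophen-2-yl is known only as a limit. The compounds shown also leave open whether the gain with chloro belongs to that atom alone, as a plain phenyl, a methoxy group or an amine on the same ring would be needed to tell.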